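Chloro for methoxycarbonyl on the aryl tail of compound 2

The source may hold more compounds than are shown below. What is called first, only, known or untested is meant among the compounds shown, and "the series" means these compounds.

Among the compounds with values here, compound 2 `COC(=O)c1ccc(CCCCCCC(=O)c2ncc(-c3ccccn3)o2)cc1` holds the lowest of the two numbers so far: in an assay for inhibition of Fatty-acid amide hydrolase 1 (Rattus norvegicus) (a higher number here means a weaker inhibitor, a lower number a stronger inhibitor), compound 2 gives 1.5 nM, while compound 1 `O=C(CCCCC#Cc1cccc(Cl)c1Cl)c1ncc(-c2ccccn2)o1` gives 5 nM, a gap beyond the usual scatter. Compound 3 `O=C(CCCCCCc1ccc(Cl)cc1)c1ncc(-c2ccccn2)o1` has not yet been measured. It differs from compound 2 by chloro in place of methoxycarbonyl on an aromatic carbon, on an aromatic carbon of a six-membered aromatic ring of carbon only. Within the data shown here, with no measured step of this kind to lean on, only a modest weakening or none beyond the scatter is expected, a 2.0-fold higher number from compound 2 to compound 3 (0.30 log units; within the scatter). Compound 3 is estimated at 3 nM, between 1 nM and 10 nM.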

Compound 3, inhibition constant: 2.7 nM
Compound 3: middle estimate off by 1.1-fold (0.05 log units), on the high side; measured number inside the range.
By their numbers in this assay, from the lowest: compounds 2, 3 and 1 (each within the scatter of the next, the first and the last beyond it).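

In this assay, chloro in place of methoxycarbonyl, para to a large group on the aryl tail, gives a 1.8-fold higher number from compound 2 to compound 3 (0.26 log units; within the scatter). This place therefore accepts a single chlorine in place of a four-atom ester with two hydrogen-bond acceptors, with no change that can be read in this assay. Still open, on these data alone, is whether an amine or a carboxylic acid at this same place would read alike, and whether chloro would read the same elsewhere on the ring. Nothing in hand accounts for why these two groups read alike.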